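From 3-carboxypropyl to 2-methoxyethyl on the shared core

A few compounds are considered here, and "the series" means these few. Any claim that something is new, unique, unknown or untested is made for them only; others in the source may bear on it.

In an ADME assay on L929 cells (Mus musculus) for cytotoxicity, read by resazurin assay, with a stated time of 48 h (on this read-out higher numbers stand for lower toxicity in this test and lower numbers for higher toxicity in this test), compound 3 (`O=C(O)CCCn1c2ccc([N+](=O)[O-])cc2c(=O)n1Cc1ccccc1`) gives > 256000 nM as a limit, not a number. Compound 2 (`O=C(O)CCn1c2ccc([N+](=O)[O-])cc2c(=O)n1Cc1ccccc1`) likewise gives > 256000 nM as a limit. Compound 1 (`C=Cn1c2ccc([N+](=O)[O-])cc2c(=O)n1Cc1ccccc1`), with vinyl on the aromatic nitrogen, gives 160000 nM as a true reading. Compound 4 (`COCCn1c2ccc([N+](=O)[O-])cc2c(=O)n1Cc1ccccc1`) has methoxy in place of carboxymethyl on a saturated chain carbon, two bonds along the chain from an aromatic nitrogen. The nearest guides, an at least 1.6-fold higher number from compound 1 to compound 2 (0.20 log units; that floor lies within the scatter) and an at least 1.6-fold higher number from compound 1 to compound 3 (0.20 log units; that floor lies within the scatter), do not clear the scatter. Like compound 4, compound 1 lacks a carboxy group and reads 160000 nM as measured, so only a small fall in this assay is expected. The expected change is an at least 1.3-fold lower number from compound 3 to compound 4 (0.12 log units; that floor lies within the scatter) and stays within the scatter. The estimate for compound 4 is 190000 nM with an expected range from 90000 nM to 350000 nM in this test.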

Compound 4, concentration lethal to 50% of the cells: > 256000 nM
Compound 4: no number, only a limit (the forecaster's own chance of this, stated with the estimate: 35%); middle value at least 1.3-fold (0.12 log units) away from the limit.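

In this assay, compound 4 shows that a chain without a carboxy group can also give a limit rather than a number, so the acid is not required for this result. Its comparison with vinyl gives an at least 1.6-fold higher number from compound 1 to compound 4 (0.20 log units; that floor lies within the scatter). The steps from compound 2 and compound 3 to compound 4 cannot be read: the limit of > 256000 nM in this assay, at which 3 of the 4 values shown sit.

Going by these compounds, the order of compounds 2, 3 and 4 stays unknown. On these data alone, it also remains open whether an amine or a longer methoxy-ending chain at this position would give a true reading in this assay.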